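Enlarging the Sulfonamide Aryl Group: Compound 1 to Compound 4

The source may hold more compounds than are shown below. What is called first, only, known or untested is meant among the compounds shown, and "the series" means these compounds.

Compound 1 `NC1=NN(c2ccccc2)C(=O)/C1=C/Nc1ccc(S(=O)(=O)Nc2ccccn2)cc1` gives 3490 nM in a functional assay on HepG2 cells (Homo sapiens) for antiproliferative activity, read by sulforhodamine B assay, with a stated time of 48 h; a lower number here means a stronger inhibitor, a higher number a weaker inhibitor.
Compound 2 `Cc1cc(C)nc(NS(=O)(=O)c2ccc(N/C=C3/C(=N)N(c4ccccc4)N=C3N)cc2)n1` gives 3760 nM.
Compound 3 `N=C1NN=C(N)/C1=C\Nc1ccc(S(=O)(=O)Nc2cnc3ccccc3n2)cc1` gives 3220 nM.

Among these three numbers compound 1 stands second highest; its neighbours compound 2 and compound 3 both lie within the usual scatter of it, so no order among the three can be read. Compound 4 `NC1=NN(c2ccccc2)C(=O)/C1=C/Nc1ccc(S(=O)(=O)Nc2cnc3ccccc3n2)cc1` differs from compound 1 in one place: quinoxalin-2-yl in place of pyridin-2-yl on a sulfonamide nitrogen. Compound 3 carries the same quinoxalin-2-yl group on a different core, and in this assay compound 3 sits within the scatter of compound 1, so no step beyond the scatter is expected in either direction. The step this expectation means is a 1.1-fold lower number from compound 1 to compound 4 (0.02 log units; within the scatter). Compound 4 is therefore estimated at 3300 nM, with a range from 1500 nM to 7500 nM.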

Compound 4, half-maximal inhibitory concentration: 3210 nM
For compound 4 the middle estimate is 1.0-fold (0.01 log units) above the measured one, and the stated range covers the measured number.
By their numbers in this assay, from the lowest: compounds 4, 3, 1 and 2 (each within the scatter of the next).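

Exchanging pyridin-2-yl for quinoxalin-2-yl on a sulfonamide nitrogen gives a 1.1-fold lower number from compound 1 to compound 4 (0.04 log units; within the scatter) in this assay on the shared core. This is the first pair shown that differs in one place, and it shows that the added six-membered aromatic ring of carbon leaves the number within the scatter at this position. Nothing measured here offers an explanation for this result. As far as these compounds go, whether phenyl, acetyl or a plain methyl group on the same nitrogen would also stay within the scatter remains open. Also open, from the compounds shown here alone, is whether this exchange reads the same on the other cores.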